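Replacing the naphthalene on the amine side of compound 1

The source may hold more compounds than are shown below. What is called first, only, known or untested is meant among the compounds shown, and "the series" means these compounds.

Measured so far:
- compound 1, `O=S(=O)(NCCCNCc1cccc2ccccc12)c1cc(C(F)(F)F)cc(C(F)(F)F)c1`: 2700 nM
- compound 2, `O=S(=O)(NCCCNCc1cccc(Cl)c1)c1cc(C(F)(F)F)cc(C(F)(F)F)c1`: 3800 nM
- compound 3, `O=S(=O)(NCCCNCc1ccccc1Cl)c1cc(C(F)(F)F)cc(C(F)(F)F)c1`: 11000 nM

All three share one core and differ only in the aromatic group on the saturated chain carbon bound to the amine nitrogen. In a functional assay on BXPC-3 cells (Homo sapiens) for inhibition, read by MTT assay, with a stated time of 72 h (a lower number here means a stronger inhibitor of growth, a higher number a weaker inhibitor of growth), compound 1 gives the lowest of the three numbers. Compound 2, carrying 3-chlorophenyl, sits nearest, with a 1.4-fold higher number from compound 1 to compound 2 (0.15 log units; within the scatter). Compound 3, carrying 2-chlorophenyl, is furthest away, with a 4.1-fold higher number from compound 1 to compound 3 (0.61 log units; beyond the scatter), and the pair of chlorophenyl isomers shows a 2.9-fold higher number from compound 2 to compound 3 (0.46 log units; beyond the scatter).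

The unmeasured compound 4, `O=S(=O)(NCCCNCc1ccc(Cl)c(C(F)(F)F)c1)c1cc(C(F)(F)F)cc(C(F)(F)F)c1`, takes the next step from compound 1:
4-chloro-3-(trifluoromethyl)phenyl in place of naphthalen-1-yl on a saturated chain carbon bound to an amine nitrogen

Within the data shown here, no measured step covers 4-chloro-3-(trifluoromethyl)phenyl itself. The closest guide is the move to 3-chlorophenyl, which stayed within the scatter, while the move to 2-chlorophenyl cost a modest amount. A single-ring replacement for naphthalen-1-yl has therefore cost little or nothing in one case and a modest amount in another. Compound 4 is accordingly expected to land close to compound 1, most likely a little higher, at an estimated 3500 nM, with a range from 1500 nM to 9000 nM, which corresponds to an expected step of a 1.3-fold higher number from compound 1 to compound 4 (0.11 log units; within the scatter).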

Compound 4, concentration for 50% growth inhibition: 7800 nM
For compound 4 the middle estimate is 2.2-fold (0.35 log units) below the measured one; the range from low to high includes it.
By their numbers in this assay, from the lowest: compounds 1 and 2 (each within the scatter of the next); then compounds 4 and 3 (each within the scatter of the next).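

In this assay, 4-chloro-3-(trifluoromethyl)phenyl is the second single-ring replacement for naphthalen-1-yl at this place to move beyond the scatter, with a 2.9-fold higher number from compound 1 to compound 4 (0.46 log units; beyond the scatter), so compound 2 is now the only single-ring compound shown that stays within the scatter of compound 1. The result for 3-chlorophenyl does not extend to this ring with two substituents, with a 2.1-fold higher number from compound 2 to compound 4 (0.31 log units; beyond the scatter), while the comparison with the 2-chlorophenyl group gives a 1.4-fold lower number from compound 3 to compound 4 (0.15 log units; within the scatter), so those two groups cannot be told apart here. Nothing available here offers an explanation for these differences.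

The compounds shown leave open how 4-chlorophenyl alone or 3-(trifluoromethyl)phenyl alone would behave, so the contributions of the two substituents on the ring of compound 4 cannot be separated. They also leave open how a ring bearing a nitrile or a carboxylic acid, or a longer chain at this place, would compare with the naphthalen-1-yl of compound 1.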